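Chloro on the benzylsulfanyl arm of the shared core

A few compounds are considered here, and "the series" means these few. Any claim that something is new, unique, unknown or untested is made for them only; others in the source may bear on it.

Two members of the series have been measured. Compound 1 `CC1=C(C(=O)Nc2ccc([N+](=O)[O-])cc2)C(c2ccc(Br)cc2)N=C(SCc2cccc(Cl)c2)N1` carries the 3-chlorobenzyl; in a functional assay on the whole organism (artery, strain albino) with Rattus norvegicus as the target, with a stated time of 600 min, at a dose of 10 mg/kg by the oral route (a higher number here means more inhibition at the dose given (going by the name of the read-out), a lower number less inhibition), compound 1 gives 5.1%. Compound 2 `CC1=C(C(=O)Nc2ccc([N+](=O)[O-])cc2)C(c2cccc([N+](=O)[O-])c2)N=C(SCc2ccccc2)N1` carries the plain benzyl and a different aryl group on the core; in this assay compound 2 gives 27.2%, the higher of the two numbers, and its gap to compound 1 lies beyond the scatter. The two compounds differ in two places; their values speak for the pair as a whole, not for one change.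

Compound 3 `CC1=C(C(=O)Nc2ccc([N+](=O)[O-])cc2)C(c2cccc([N+](=O)[O-])c2)N=C(SCc2cccc(Cl)c2)N1` is compound 2 with chloro in place of hydrogen on an aromatic carbon, meta to a large group. Within the data shown here, no measured pair isolates this change. Compound 1, which also carries the 3-chlorobenzyl, sits low in this assay, but its other difference from compound 2 is not separated out. The step of a number 6.2 percentage points lower from compound 2 to compound 3 (within the scatter) is expected to be small and downward, within the scatter. Compound 3 is estimated at 21%, within 7% to 36%.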

Compound 3, a percentage reported as inhibition, in the whole organism at one dose (the size of the read-out at that dose, not a potency): 19%
Compound 3: the middle estimate sits 2 percentage points above what was measured; the measured number falls inside the stated range.
By their numbers in this assay, from the lowest: compound 1; then compounds 3 and 2 (each within the scatter of the next).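

In this assay, chloro in place of hydrogen on an aromatic carbon of the benzyl arm gives a number 8.2 percentage points lower from compound 2 to compound 3 (within the scatter), so at this position the change cannot be told apart from the scatter. With the 3-chlorobenzyl held fixed, 3-nitrophenyl in place of 4-bromophenyl on a saturated ring carbon gives a number 13.9 percentage points higher from compound 1 to compound 3 (beyond the scatter), a modest step, which ties the low number of compound 1 to its 4-bromophenyl rather than to the chloro. Nothing available explains either step.

The compounds shown leave open whether a methoxy group, an amine or a carboxylic acid on the same aromatic carbon would move the number beyond the scatter. They also leave open whether the step between the two aryl groups would hold with the plain benzyl.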